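The compounds below may be only part of what the source reports. "The series", "measured", "known", "first", "only" and "open" are said of these compounds alone.

Working notes on the series. The compounds share one core; compound 1 `COc1cc(Oc2cccc(Nc3ccccc3)c2)cc(OC)c1CNCc1ccc(Cl)cc1` carries a 4-chlorobenzyl on the amine nitrogen, compound 2 `COc1cc(Oc2cccc(Nc3ccccc3)c2)cc(OC)c1CNC1CC1` a cyclopropyl, and compound 3 `COc1cc(Oc2cccc(Nc3ccccc3)c2)cc(OC)c1CNC(C)C` an isopropyl. In a functional assay on HCT-15 cells (Homo sapiens) for inhibition, read by MTT assay, with a stated time of 72 h (a lower number here means a stronger inhibitor, a higher number a weaker inhibitor), compound 1 gives 4850 nM. In this assay compound 2 gives 6140 nM, the number that stands highest of the two numbers shown, although the gap of a 1.3-fold higher number from compound 1 to compound 2 (0.10 log units; within the scatter) is within the scatter. Compound 3 in this assay is reported only as a limit, > 20000 nM; this is the limit of > 20000 nM in this assay, at which 1 of the 3 values shown sits. The steps of an at least 4.1-fold higher number from compound 1 to compound 3 (0.61 log units; beyond the scatter) and an at least 3.2-fold higher number from compound 2 to compound 3 (0.51 log units; beyond the scatter) are accordingly lower bounds on the loss with isopropyl.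

Compound 4 `COc1cc(Oc2cccc(Nc3ccccc3)c2)cc(OC)c1CNCc1ccc(F)cc1` is not yet measured; its change from compound 2 is 4-fluorobenzyl in place of cyclopropyl on an amine nitrogen. The step that bears on it is a 1.3-fold higher number from compound 1 to compound 2 (0.10 log units; within the scatter), read in reverse: a benzyl-type group in place of cyclopropyl left the number essentially where it was. Within the data shown here, compound 4 differs from compound 1 only by 4-fluorobenzyl in place of 4-chlorobenzyl, a swap for which no measured pair exists here. In this assay a step of a 1.3-fold lower number from compound 2 to compound 4 (0.11 log units; within the scatter) is therefore expected, not beyond the scatter. Compound 4 is estimated at 4800 nM, with a range of 2400 nM to 9600 nM.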

Compound 4, half-maximal inhibitory concentration: 3640 nM
For compound 4 the middle estimate is 1.3-fold (0.12 log units) above the measured one, within the range that was stated.
By their numbers in this assay, from the lowest: compounds 4, 1 and 2 (each within the scatter of the next). At a limit, above all of these: compound 3.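

In this assay, among these compounds, the first measured halogen swap on the benzyl group gives a 1.3-fold lower number from compound 1 to compound 4 (0.12 log units; within the scatter), so fluoro in place of chloro on an aromatic carbon leaves the two numbers within the scatter of each other. Among the compounds shown here, the other direct comparison on the amine nitrogen gives a 1.7-fold lower number from compound 2 to compound 4 (0.23 log units; within the scatter), so 4-fluorobenzyl, with its six-membered aromatic ring, and cyclopropyl, with its three-membered non-aromatic ring, are not told apart here, and compounds 1, 2 and 4 form one group in which no member is separated from the others. Only isopropyl stands apart among the four groups, and the step of an at least 5.4-fold lower number from compound 3 to compound 4 (0.73 log units; beyond the scatter) is a lower bound on the gap, since the entry for compound 3 is a limit and not a number: the limit of > 20000 nM in this assay, at which 1 of the 4 values shown sits.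

The compounds shown leave open why cyclopropyl stays with the two halogenated benzyl groups while isopropyl does not, and how large the gap to isopropyl really is. They also leave open whether an unsubstituted benzyl, a longer alkyl chain or a hydroxyethyl group on the amine nitrogen would fall with compounds 1, 2 and 4 or with compound 3.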